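Pyridin-2-yl for 4-methylphenyl on the ring amide nitrogen

A few compounds are considered here, and "the series" means these few. Any claim that something is new, unique, unknown or untested is made for them only; others in the source may bear on it.

Three compounds of this series have numbers in a functional assay on SK-BR-3 cells (Homo sapiens) for cytotoxicity, read by sulforhodamine B assay, with a stated time of 48 h; a lower number here means a stronger inhibitor, a higher number a weaker inhibitor. Compound 1 `CO[C@@H]1CC=C2NN(c3ccc([N+](=O)[O-])cc3)C(=O)CC[C@]2(c2ccccc2)O1` gives 7700 nM. Going by the values given here, compound 2 `CO[C@@H]1CC=C2NN(c3c[nH]c4ccccc34)C(=O)CC[C@]2(c2ccccc2)O1` gives 1200 nM, and the only single-point step among the measured compounds is a 6.4-fold lower number from compound 1 to compound 2 (0.81 log units; beyond the scatter). Compound 3 `CO[C@@H]1CC=C2N(c3ccc(C)cc3)C(=O)C[C@]2(c2ccccc2)O1`, which carries a smaller ring and no second nitrogen in that ring, gives 1100 nM; this value and that of compound 2 lie within the scatter of each other, while the gap to compound 1 is beyond it, so compound 3 sits at the low end of the numbers shown without being separable from compound 2.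

Compound 4 `CO[C@@H]1CC=C2N(c3ccccn3)C(=O)C[C@]2(c2ccccc2)O1` is not yet measured. It differs from compound 3 in one place: pyridin-2-yl in place of 4-methylphenyl on an amide-type nitrogen in a ring. Among the compounds with values here, the one measured step bears on this only loosely: it also changes the group on the amide-type nitrogen, but on the other core, and it swaps a phenyl for a bicyclic heteroaryl rather than trimming a methyl and adding a ring nitrogen. Within the data shown here, no measured pair shows a pyridinyl on this nitrogen. The expectation for compound 4 is therefore a step of a 1.5-fold higher number from compound 3 to compound 4 (0.16 log units; within the scatter), most likely not beyond the scatter, with a slight lean toward a higher number. The estimate for compound 4 in this assay is 1600 nM, within 500 nM to 5000 nM.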

Compound 4, half-maximal inhibitory concentration: 1100 nM
Beside the measured number, compound 4's estimate is 1.5-fold (0.16 log units) above it, within the range that was stated.
By their numbers in this assay, from the lowest: compounds 3, 4 and 2 (each within the scatter of the next); then compound 1.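

In this assay, going by these compounds alone, pyridin-2-yl in place of 4-methylphenyl on the amide-type nitrogen gives no change at the digits printed from compound 3 to compound 4 (within the scatter), the only readable one-place step on the core of compound 3. This swap removes the methyl and adds a ring nitrogen together, and the pair cannot separate those two changes; the only earlier step on such a nitrogen, a 6.4-fold lower number from compound 1 to compound 2 (0.81 log units; beyond the scatter), lies on the other core and is beyond the scatter, so the size of a change at this nitrogen is not shown to carry from one core to the other. No supporting measurement accounts for the unchanged number.

Open, as far as these compounds go, is whether the number also holds with an unsubstituted phenyl, with pyridin-3-yl, or with an aryl group carrying an amine or a carboxylic acid on this nitrogen. Also open, from the compounds shown here alone, is whether 4-nitrophenyl and 1H-indol-3-yl, placed on the core of compound 3, would separate as they do on the core of compound 1.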